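From Compound 3 to Compound 4: Changing the Chain

The source may hold more compounds than are shown below. What is called first, only, known or untested is meant among the compounds shown, and "the series" means these compounds.

Compound 1 `CCCCCCCCNC(=O)[C@@H]1CSC(c2cc(OC)c(OC)c(OC)c2)N1`, compound 2 `CCCCCCCCCCNC(=O)[C@@H]1CSC(c2ccc(OC)c(OC)c2)N1` and compound 3 `CCCCCCCCCCCCCCCNC(=O)[C@@H]1CSC(c2ccc(NC(C)=O)cc2)N1` share a core and each carry a long chain on an amide, but they differ from one another in more than one place. In an ADME assay on cells (Fibroblast, Homo sapiens) for antiproliferative activity, read by sulforhodamine B assay, with a stated time of 48 h (on this read-out higher numbers stand for weaker inhibition and lower numbers for stronger inhibition), compound 3 gives 14300 nM. That number lies within the usual scatter of compound 1 at 20800 nM, while compound 2 at 6300 nM shows a lower number, beyond the scatter, which means stronger inhibition.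

Compound 4 `CCCCCCCCC/C=C\CCCCCCCNC(=O)[C@@H]1CSC(c2ccc(NC(C)=O)cc2)N1` keeps everything in compound 3 except the chain: a group of 11 heavy atoms (11 carbon; no ring) in place of a group of 8 heavy atoms (8 carbon; no ring), on a saturated chain carbon, seven bonds along the chain from an amide-type nitrogen. The change falls on a saturated chain carbon, seven bonds along the chain from an amide-type nitrogen, and the part that enters holds a double bond outside aromatic rings.

Within the data shown here, no two measured compounds differ in one place only, so the data give no direct measure of a chain change. Still, compound 2 at 6300 nM and compound 1 at 20800 nM mark the whole measured span despite their different chains, so no large change is expected here. In this assay, the expected result is a 1.1-fold lower number from compound 3 to compound 4 (0.04 log units; within the scatter), a step within the scatter and with no clear direction. The estimate for compound 4 is 13000 nM, with an expected range from 5500 nM to 30000 nM.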

Compound 4, half-maximal inhibitory concentration: 10600 nM
Beside the measured number, compound 4's estimate is 1.2-fold (0.09 log units) above it; measured number inside the range.
By their numbers in this assay, from the lowest: compounds 2, 4, 3 and 1 (each within the scatter of the next, the first and the last beyond it).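

Among these compounds, this is the first comparison in which only one place differs, and it gives a direct reading for the chain. In this assay, replacing the octyl group with a group of 11 heavy atoms (11 carbon; no ring) that holds a double bond outside aromatic rings, on a saturated chain carbon, seven bonds along the chain from an amide-type nitrogen, gives a 1.3-fold lower number from compound 3 to compound 4 (0.13 log units; within the scatter), so this assay shows no clear effect from this change and this position tolerates it without a measurable loss or gain. Nothing measured here speaks to why the number stays within the scatter.

The step brings added carbon atoms and a double bond together, so the compounds shown cannot separate the contribution of one from the other, and a fully saturated chain of the same length would be needed to tell them apart. On these data alone, it also remains open whether this place stays as tolerant with a very different group, such as a carboxylic acid or an amine, on the chain.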